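Removing the phenyl from the fused core: stability notes

The source may hold more compounds than are shown below. What is called first, only, known or untested is meant among the compounds shown, and "the series" means these compounds.

Four analogues share the rest of the molecule and differ only in the fused core and its substituent. Compound 1 `CCCNC(=O)C1CCN(C(=O)c2cc3scnc3n2Cc2ccc(OC)cc2)CC1` and compound 2 `CCCNC(=O)C1CCN(C(=O)c2cc3sc(-c4ccccc4)nc3n2Cc2ccc(OC)cc2)CC1` share one core; compound 3 `CCCNC(=O)C1CCN(C(=O)c2cc3sc(-c4ccccc4)cc3n2Cc2ccc(OC)cc2)CC1` and compound 4 `CCCNC(=O)C1CCN(C(=O)c2cc3sccc3n2Cc2ccc(OC)cc2)CC1` share another, and the difference between the two cores is not broken down here. In an ADME assay on microsomes from liver (Homo sapiens) for metabolic stability (a lower number here means that the compound disappears faster, a higher number that the compound lasts longer), compound 1 gives 0.462 h, compound 2 gives 0.68 h and compound 3 gives 0.737 h. The change from compound 2 to compound 1 is hydrogen in place of phenyl on an aromatic carbon and gives a 1.5-fold lower number from compound 2 to compound 1 (0.17 log units; within the scatter). The change from compound 3 to compound 4 is hydrogen in place of phenyl on an aromatic carbon. It is the same kind of change, though the place differs: in compound 2 the ring has 1 nitrogen and 1 sulfur and the carbon is next to the ring nitrogen and next to the ring sulfur, while in compound 3 the ring has 1 sulfur and the carbon is next to the ring sulfur. In this assay, within the data shown here, the step expected is a 1.5-fold lower number from compound 3 to compound 4 (0.17 log units; within the scatter), because the only precedent is a 1.5-fold lower number from compound 2 to compound 1 (0.17 log units; within the scatter). Compound 4 is therefore expected to give about 0.5 h, between 0.3 h and 0.85 h.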

Compound 4, half-life: 0.177 h
For compound 4 the middle estimate is 2.8-fold (0.45 log units) above the measured one, and the stated range ends above it.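

In this assay, hydrogen in place of phenyl on an aromatic carbon gives a 4.2-fold lower number from compound 3 to compound 4 (0.62 log units; beyond the scatter) on the core of compound 3. The size of this change therefore does not carry over directly between the two cores, and a step read on one core is a poor guide to the step on the other. With one pair per core, the notes do not show which feature of the core sets the size of the step, or how the change would behave on any further core, but the two steps do differ: the same change on two cores in this assay, a 1.5-fold lower number (0.17 log units; within the scatter) from compound 2 to compound 1 and a 4.2-fold lower number (0.62 log units; beyond the scatter) from compound 3 to compound 4, 2.8-fold (0.45 log units) apart, beyond the scatter of two such steps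

Still open, from the compounds shown here alone, is whether the low half-life of compound 4 follows from the loss of the phenyl itself or whether other groups on the same carbon, next to the ring sulfur, would serve as well. Compounds with methyl, a methoxy group or an amine there would address this on both cores.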